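A few compounds are considered here, and "the series" means these few. Any claim that something is new, unique, unknown or untested is made for them only; others in the source may bear on it.

Measured compounds:
- compound 1 `O=C(CCc1ccc(C(F)(F)F)cc1)Nc1ccc2nc(N3CCCCCC3)ccc2c1` gives 36 nM in an assay on isolated protein for displacement of a labelled ligand from melanin-concentrating hormone receptor 1 (Homo sapiens); a lower number here means a stronger inhibitor, a higher number a weaker inhibitor
- compound 2 `CCN(CC)c1ccc2cc(NC(=O)CCc3ccc(C(F)(F)F)cc3)ccc2n1` gives 88 nM in this assay
- compound 3 `O=C(CCc1ccc(C(F)(F)F)cc1)Nc1ccc2nc(N3CCC3)ccc2c1` gives 4 nM in this assay

Among these three numbers compound 1 stands second highest. Its nearest neighbour is compound 2, at a 2.4-fold higher number from compound 1 to compound 2 (0.39 log units; beyond the scatter), and its furthest is compound 3, at a 9.0-fold lower number from compound 1 to compound 3 (0.95 log units; beyond the scatter). All three compounds share the same core and differ only in the group on the aromatic carbon next to the ring nitrogen.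

Compound 4 `CC(C)C(=O)NC1CCN(c2ccc3cc(NC(=O)CCc4ccc(C(F)(F)F)cc4)ccc3n2)C1` has not yet been measured in this assay. It differs from compound 1 in one place: 3-((isopropylcarbonyl)amino)pyrrolidin-1-yl in place of azepan-1-yl on an aromatic carbon. The two measured steps that bear on this are the ones from compound 1, since both also swap out azepan-1-yl at this same aromatic carbon. Swapping in an open-chain diethylamino gave a 2.4-fold higher number from compound 1 to compound 2 (0.39 log units; beyond the scatter), while the much smaller azetidin-1-yl ring gave a 9.0-fold lower number from compound 1 to compound 3 (0.95 log units; beyond the scatter). Among the measured compounds shown here, a five-membered ring sits between those two ring sizes, but the added amide-bearing substituent has no counterpart among the measured compounds, so the expectation rests on thin ground. A modest step downward, or none beyond the scatter, is expected in this assay. For compound 4 the estimate is 20 nM, within 5 nM to 80 nM, which would mean an expected step of a 1.8-fold lower number from compound 1 to compound 4 (0.26 log units; within the scatter).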

Compound 4, half-maximal inhibitory concentration: 1 nM
Compound 4: the middle estimate sits 20-fold (1.30 log units) above what was measured; the measured number lies below the stated range.
By their numbers in this assay, from the lowest: compound 4; then compound 3; then compound 1; then compound 2.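

In this assay, the aromatic carbon next to the ring nitrogen tolerates far more than compound 1, compound 2 and compound 3 could show: 3-((isopropylcarbonyl)amino)pyrrolidin-1-yl, with its carbonyl and amide hydrogen, gives a 36-fold lower number from compound 1 to compound 4 (1.56 log units; beyond the scatter) and an 88-fold lower number from compound 2 to compound 4 (1.94 log units; beyond the scatter) while also being the largest group tried here. Until now the small azetidin-1-yl ring held the lowest number, which might have suggested that less bulk at this carbon was better, but compound 4 goes against that reading, with a 4.0-fold lower number from compound 3 to compound 4 (0.60 log units; beyond the scatter) and the strongest binding of the four compounds. No measurement shown here explains why this group does so well.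

The ring and its amide side chain enter together, so the plain pyrrolidin-1-yl ring, or the same ring carrying a free amine in place of the amide, would be needed to show which part accounts for the gain. From the compounds shown here alone, it also remains open whether the isopropyl end of the amide matters, for instance whether a longer chain or a carboxylic acid there would keep the number this low.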